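The compounds below may be only part of what the source reports. "The series", "measured", "known", "first", "only" and "open" are said of these compounds alone.

Measured in a functional assay on A2780 cells (Homo sapiens) for antiproliferative activity, read by sulforhodamine B assay, with a stated time of 72 h (on this read-out higher numbers stand for weaker inhibition and lower numbers for stronger inhibition), the compounds so far read:

compound 1 `O=C(NCc1ccc(S(=O)(=O)c2cc(F)cc(F)c2)cc1)c1cc2ccncc2o1` gives 9 nM
compound 2 `O=C(NCc1ccc(S(=O)(=O)N2CCOCC2)cc1)c1cc2ccncc2o1` gives 132 nM
compound 3 `O=C(NCc1ccc(S(=O)(=O)N2CCOCC2)cc1)c1cc2cnccc2[nH]1` gives 37 nM

Compound 3 stands in the middle of these three values, with compound 1 lower and compound 2 higher, both gaps beyond the scatter. Compound 4 `O=C(NCc1ccc(S(=O)(=O)C2CCOCC2)cc1)c1cc2cnccc2[nH]1` keeps the rest of compound 3 and differs in one group: oxan-4-yl in place of morpholin-4-yl on a sulfonyl sulfur. The step that bears most directly on this change is a 15-fold higher number from compound 1 to compound 2 (1.17 log units; beyond the scatter), a large one at the same sulfur, where morpholin-4-yl came with the higher number. The modest step of a 3.6-fold lower number from compound 2 to compound 3 (0.55 log units; beyond the scatter) lies elsewhere in the molecule and bears on it only as background. For the measured compounds named here, no measured compound carries oxan-4-yl, so only part of the large step is expected to carry over. A modest move towards a lower number is therefore expected, an estimated 2.5-fold lower number from compound 3 to compound 4 (0.39 log units; beyond the scatter) in this assay. Compound 4 is estimated at 15 nM, with an expected range from 5 nM to 45 nM.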

Compound 4, half-maximal inhibitory concentration: 47 nM
Estimate against measurement, compound 4: 3.1-fold (0.50 log units) below; measured number above the stated range.
By their numbers in this assay, from the lowest: compound 1; then compounds 3 and 4 (each within the scatter of the next); then compound 2.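

In this assay, for the compounds shown here, oxan-4-yl in place of morpholin-4-yl on the sulfonyl sulfur gives a 1.3-fold higher number from compound 3 to compound 4 (0.10 log units; within the scatter) and so does not separate compound 3 from compound 4, even though the ring nitrogen of the one group gives way to a carbon in the other. Going by these compounds alone, the large step seen earlier at this sulfur, a 15-fold higher number from compound 1 to compound 2 (1.17 log units; beyond the scatter), therefore finds no counterpart in this exchange of one six-membered non-aromatic ring for another. Nothing measured on these compounds accounts for this result.

On these data alone, it remains open whether 3,5-difluorophenyl on the sulfonyl sulfur would bring the same large step on the core of compound 3 as it does on the core of compound 1. Also open, as far as these compounds go, is how a smaller group such as methyl, or an open-chain amine, would read at this sulfur.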